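The compounds below may be only part of what the source reports. "The series", "measured", "known", "first", "only" and "open" are said of these compounds alone.

Compound 1 `Nc1nc(NC2CCCCC2)cc(-c2cc(N3C[C@H](O)[C@@H](O)C3)ccc2O)n1`: 900 nM
Compound 2 `Nc1nc(-c2cc(N3C[C@H](O)[C@@H](O)C3)ccc2O)cc(C2CCNCC2)n1`: > 10000 nM (a limit, not a number)

Both compounds were tested in a functional assay on HCT-116 cells (Homo sapiens) for cytotoxicity, with a stated time of 48 h; a lower number here means a stronger inhibitor of growth, a higher number a weaker inhibitor of growth. Compound 2 gives only a limit, > 10000 nM, and so sits at the limit of > 10000 nM in this assay, at which 1 of the 2 values shown sits.

Compound 3 `Nc1nc(-c2cc(N3C[C@H](O)[C@@H](O)C3)ccc2O)cc(C2CCCNC2)n1` differs from compound 2 in one place, with piperidin-3-yl in place of piperidin-4-yl on an aromatic carbon. For the measured compounds named here, only one measured step bears on this place: an at least 11-fold higher number from compound 1 to compound 2 (1.04 log units; beyond the scatter). That large step, beyond the scatter, replaced cyclohexylamino with piperidin-4-yl. Going by the values given here, it shows that a change here can matter, but no measured pair compares piperidin-3-yl with piperidin-4-yl. Compound 3 does not regain cyclohexylamino, so no recovery is expected, and no step beyond the scatter is expected in either direction in this assay.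

The expected step is a number no higher from compound 2 to compound 3 (the limit leaves the size open). For compound 3 the estimated value is 10000 nM, with an expected range of 3000 nM to 30000 nM.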

Compound 3, concentration for 50% growth inhibition: > 10000 nM
Compound 3 gave a limit, no number (the forecaster's own chance of this, stated with the estimate: 60%); the middle value sits exactly at the limit.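

In this assay, piperidin-3-yl in place of cyclohexylamino gives an at least 11-fold higher number from compound 1 to compound 3 (1.04 log units; beyond the scatter), so the loss of growth inhibition seen with piperidin-4-yl also appears when the piperidine is attached through a different ring carbon. The step between compound 2 and compound 3 cannot be read, since both values are limits. Neither piperidine attachment therefore brings back a measurable value, and the series now shows this shared ceiling: the limit of > 10000 nM in this assay, at which 2 of the 3 values shown sit.

From the compounds shown here alone, how far compound 2 and compound 3 lie beyond that limit, and whether they differ from each other, remains open. Also open, going by these compounds, is whether the weaker growth inhibition goes with the ring nitrogen or with the lost amino link to the ring, a question that a directly attached cyclohexyl group or a piperidin-4-ylamino group would help to separate.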